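This account rests on a few compounds, and the source may have more. Where it says the series, first, only, none or still open, it means among the compounds named here.

Measured so far in a functional assay on SMMC-7721 cells (Homo sapiens) for inhibition, read by CCK-8 assay, with a stated time of 72 h, tested at 2 uM; a higher number here means more inhibition of growth at the concentration tested, a lower number less inhibition of growth:
Compound 1 `COc1ccc(SCc2ccc(C(=O)Nc3ccccc3N)cc2)cc1` gives 33.1%
Compound 2 `CCc1ccc(SCc2ccc(C(=O)Nc3ccccc3N)cc2)cc1` gives 25.7%

Compound 2 holds the lower of the two numbers in this assay, with compound 1 nearest; the step of a number 7.4 percentage points lower from compound 1 to compound 2 (within the scatter) is within the scatter. Compound 3 `Nc1ccccc1NC(=O)c1ccc(CSc2cccc(F)c2)cc1` differs from compound 2 by 3-fluorophenyl in place of 4-ethylphenyl on a sulfur. Within the data shown here, only that single step bears on it, and it too changed the group on the sulfur without moving the number beyond the scatter. An expected step for compound 3 of a number 2.3 percentage points higher from compound 2 to compound 3 (within the scatter) therefore stays within the scatter. Compound 3 is estimated at 28%, between 12% and 45%.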

Compound 3, percent growth inhibition at one concentration: 18.6%
Beside the measured number, compound 3's estimate is 9.4 percentage points above it; low and high end bracket the measured number.
By their numbers in this assay, from the lowest: compounds 3, 2 and 1 (each within the scatter of the next, the first and the last beyond it).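

In this assay, changing the group on the sulfur now gives a step beyond the scatter: with 3-fluorophenyl in place of 4-methoxyphenyl, the result is a number 14.5 percentage points lower from compound 1 to compound 3 (beyond the scatter). With 3-fluorophenyl in place of 4-ethylphenyl, the result is a number 7.1 percentage points lower from compound 2 to compound 3 (within the scatter), so the effect of this change depends on the group it replaces. No supporting data explain this difference. Still open, on these data alone, is whether 4-fluorophenyl would read like 3-fluorophenyl, which would separate the fluorine from its place on the ring. Also open, as far as these compounds go, is how a butyl chain on the sulfur would compare.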